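Adding a methoxy group to three weakly cytotoxic compounds

This account rests on a few compounds, and the source may have more. Where it says the series, first, only, none or still open, it means among the compounds named here.

Compound 1 `COc1ccc(CNc2ncnc3c2ncn3C2CCCCO2)cc1`: > 100000 nM
Compound 2 `COc1ccc(CNc2ncnc3c2ncn3C2CCCCO2)c(OC)c1`: > 25000 nM
Compound 3 `COc1cc(CNc2ncnc3c2ncn3C2CCCO2)cc(OC)c1`: > 100000 nM

In an ADME assay on K562 cells (Homo sapiens) for cytotoxicity, with a stated time of 72 h (a lower number here means a stronger inhibitor, a higher number a weaker inhibitor), compound 1 gives only a limit, > 100000 nM. Compound 2 also gives only a limit in this assay, > 25000 nM. The change methoxy in place of hydrogen on an aromatic carbon therefore yields a step that the two limits leave unreadable from compound 1 to compound 2, since both ends rest on limits, the limit of > 100000 nM in this assay, at which 2 of the 3 values shown sit, and (the limit of > 25000 nM in this assay, at which 1 of the 3 values shown sits). Compound 3 likewise gives only a limit in this assay, > 100000 nM. How the core of compound 3 differs from that of compound 1 is not broken down here.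

Compound 4 `COc1cc(CNc2ncnc3c2ncn3C2CCCO2)cc(OC)c1OC` has not yet been measured. It differs from compound 3 by methoxy in place of hydrogen on an aromatic carbon, the same kind of change as from compound 1 to compound 2, though here the place is ortho to two methoxy groups and para to a large group rather than ortho to a large group and meta to a methoxy group. With all three values at limits, the step from compound 3 to compound 4 is expected to be a number no higher from compound 3 to compound 4 (the limit leaves the size open), and compound 4 is estimated at 100000 nM in this assay.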

Compound 4, half-maximal inhibitory concentration: > 100000 nM
Compound 4 gave a limit, no number; the forecaster's own chance of this, stated with the estimate: 85%; the middle value sits exactly at the limit.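

Compound 3 and compound 4 both rest on limits, so no step can be read between them. The compounds shown leave open whether adding a methoxy group changes cytotoxicity at all, and how strong any of the four compounds actually is.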